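The compounds below may be only part of what the source reports. "The series", "measured", "known", "first", "only" and "open" are said of these compounds alone.

Within the data shown here, in a functional assay on SW480 cells (Homo sapiens) for antiproliferative activity, read by MTT assay, with a stated time of 48 h (a lower number here means a stronger inhibitor, a higher number a weaker inhibitor), three compounds built on one shared core have numbers so far. Compound 1 `C=C(CO)C(CCCCCC)n1cnc2c(Cl)ncnc21` gives 32000 nM, and compound 3 `C=C(CO)C(CCCCCCC)n1cnc2c(Cl)ncnc21`, which keeps the same 1-(hydroxymethyl)ethenyl group on a longer chain, gives 29400 nM. Compound 2 `CCCCCCCC(CCO)n1cnc2c(Cl)ncnc21`, which carries 2-hydroxyethyl in place of that group, gives 3630 nM. Compound 3 therefore stands level with compound 1 and clearly above compound 2, and a higher number here means a weaker inhibitor.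

The next compound, compound 4 `C=C(CO)C(CCCCCCCC)n1cnc2c(Cl)ncnc21`, differs from compound 3 by methyl in place of hydrogen on a saturated chain carbon, eight bonds along the chain from an aromatic nitrogen and a double-bonded chain carbon. The chain simply grows once more, and the group bearing the hydroxyl stays as it was. The closest guide is the same swap made seven bonds along the chain rather than eight, a 1.1-fold lower number from compound 1 to compound 3 (0.04 log units; within the scatter). The other measured step, an 8.1-fold higher number from compound 2 to compound 3 (0.91 log units; beyond the scatter), changes a different group, so it says little about this extension. One small step is thin evidence, and nothing measured yet shows how a still longer chain behaves. Even so, the expectation is no change beyond the scatter, and the estimated step is a 1.1-fold lower number from compound 3 to compound 4 (0.04 log units; within the scatter). For compound 4 the estimated value is 27000 nM, with an expected range of 13000 nM to 50000 nM.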

Compound 4, half-maximal inhibitory concentration: 16200 nM
For compound 4 the middle estimate is 1.7-fold (0.22 log units) above the measured one, and the stated range covers the measured number.
By their numbers in this assay, from the lowest: compound 2; then compounds 4, 3 and 1 (each within the scatter of the next).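

In this assay, adding methyl on the saturated chain carbon eight bonds along the chain gives a 1.8-fold lower number from compound 3 to compound 4 (0.26 log units; within the scatter), so this further extension, like the one before it, produces no step beyond the scatter. The longest reach available here, ethyl in place of hydrogen seven bonds along the chain, gives a 2.0-fold lower number from compound 1 to compound 4 (0.30 log units; within the scatter), so even the combined extension stays within the scatter, and among compound 1, compound 3 and compound 4 this end of the chain shows no measurable dependence on its length. No supporting measurement bears on why the numbers behave this way.

Still open, as far as these compounds go, is whether a longer chain at this place would at some length produce a real step, and whether an amine or a carboxylic acid at the far end of the chain would do so where added methyl does not. Among these compounds, compound 2 is the only compound here with 2-hydroxyethyl, so it also remains open whether chain length matters any more when that group replaces 1-(hydroxymethyl)ethenyl.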